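The source may hold more compounds than are shown below. What is called first, only, known or untested is meant among the compounds shown, and "the series" means these compounds.

In a functional assay on SW1573 cells (Homo sapiens) for antiproliferative activity, read by sulforhodamine B assay, with a stated time of 48 h (a higher number here means a weaker inhibitor of growth, a lower number a stronger inhibitor of growth), compound 1 `CCC(C#CC(=O)OC)O/C=C/C(=O)OC` gives 540 nM, the lowest of the three numbers recorded. Compound 2 `COC(=O)C#CC(C[C@@H](C)CCC=C(C)C)O/C=C/C(=O)OC` gives 2200 nM in this assay, and compound 3 `CCOC(=O)C#CC(C[C@@H](C)CCC=C(C)C)O/C=C/C(=O)OCC` gives 2600 nM; both stand beyond the scatter from compound 1. Compound 4 `COC(=O)C#CC(O/C=C/C(=O)OC)C(C)C` has not yet been tested. It differs from compound 1 by one change: methyl in place of hydrogen on a saturated chain carbon bound to two saturated chain carbons. Among the compounds with values here, no pair of measured compounds differs in a single place, so the data give no measured step against which to judge a change this small. The expected step is a 1.3-fold higher number from compound 1 to compound 4 (0.11 log units; within the scatter), a slightly higher number but within the scatter. Compound 4 is therefore expected to give an estimated 700 nM in this assay, with a likely range from 300 nM to 1600 nM.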

Compound 4, concentration for 50% growth inhibition: 750 nM
For compound 4 the middle estimate is 1.1-fold (0.03 log units) below the measured one; the measured number falls inside the stated range.
By their numbers in this assay, from the lowest: compounds 1 and 4 (each within the scatter of the next); then compounds 2 and 3 (each within the scatter of the next).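

In this assay, the change from ethyl to isopropyl, methyl in place of hydrogen on a saturated chain carbon bound to two saturated chain carbons, gives a 1.4-fold higher number from compound 1 to compound 4 (0.14 log units; within the scatter). Within the data shown here, this is the first single-place step available, and it shows that this position accepts one added methyl with no readable change in growth inhibition. The data offer no measured explanation for this result. Going by these compounds, it remains open whether a longer chain, a phenyl ring or an amine at this position would also leave the number within the scatter.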